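The compounds below may be only part of what the source reports. "The series", "measured", "known", "first", "only" and "open" are said of these compounds alone.

Values so far in an ADME assay on HepG2 cells (Homo sapiens) for inhibition, read by fluorescence and resazurin assay, with a stated time of 72 h; on this read-out lower numbers stand for stronger inhibition and higher numbers for weaker inhibition:
- compound 1 (`Cc1ccc(Nc2nccc(Nc3ccc4nc[nH]c4c3)n2)cc1`) gives > 25000 nM as a limit of the assay
- compound 2 (`NS(=O)(=O)c1cccc(Nc2nccc(Nc3ccc4nc[nH]c4c3)n2)c1`) gives > 25000 nM as a limit of the assay
- compound 3 (`Cc1cccc(Nc2ncc(C)c(Nc3ccc4nc[nH]c4c3)n2)c1`) gives 6600 nM as a measured number

Among the compounds with values here, compound 3 is the only compound here with a number rather than a limit. Compound 4 (`Cc1cccc(Nc2ncc([N+](=O)[O-])c(Nc3ccc4nc[nH]c4c3)n2)c1`) carries nitro in place of methyl on an aromatic carbon. Within the data shown here, no measured pair isolates this change, so the expectation is loose. A modest gain in inhibition in this assay is expected, estimated as a 1.7-fold lower number from compound 3 to compound 4 (0.22 log units; within the scatter) and possibly no larger than the scatter. The estimated value for compound 4 is 4000 nM (expected range 1000 nM to 20000 nM).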

Compound 4, half-maximal inhibitory concentration: 22000 nM
Beside the measured number, compound 4's estimate is 5.5-fold (0.74 log units) below it, and the stated range ends below it.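

Within the data shown here, this is the first step that isolates one position. In this assay, nitro in place of methyl on the aromatic carbon two atoms from the ring nitrogen gives a 3.3-fold higher number from compound 3 to compound 4 (0.52 log units; beyond the scatter), so this position does affect the read-out, and this change weakens inhibition. Any further loss at this carbon would be hard to size: the limit of > 25000 nM in this assay, at which 2 of the 4 values shown sit.

From the compounds shown here alone, whether the loss is specific to nitro or extends to other groups at this carbon, such as an amine or a nitrile, remains open.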